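An Aryl Amide Swap on a Shared Core

The compounds below may be only part of what the source reports. "The series", "measured", "known", "first", "only" and "open" are said of these compounds alone.

Four compounds share one core and differ only in the group on a carbonyl carbon: compound 1 `CC(=O)Nc1ccc2ncc(-c3cnn(C)c3)cc2n1`, compound 2 `Cn1cc(-c2cnc3ccc(NC(=O)C4CC4)nc3c2)cn1`, compound 3 `COc1ccc(C(=O)Nc2ccc3ncc(-c4cnn(C)c4)cc3n2)cc1` and the not yet measured compound 4 `Cn1cc(-c2cnc3ccc(NC(=O)c4cccnc4)nc3c2)cn1`. They were compared in a functional assay on HeLa cells (Homo sapiens) for antiproliferative activity, read by MTT assay, with a stated time of 48 h; a lower number here means a stronger inhibitor, a higher number a weaker inhibitor. For compound 1 the assay reports only a limit, > 50000 nM. For compound 2 it likewise reports a limit, > 50000 nM. For the measured compounds named here, compound 3 gives 4900 nM, the only number in the set; the other two results sit at the limit of > 50000 nM in this assay, at which 2 of the 3 values shown sit. Accordingly the step that the two limits leave unreadable from compound 1 to compound 2 cannot be read, whereas the steps of an at least 10-fold lower number from compound 1 to compound 3 (1.00 log units; beyond the scatter) and an at least 10-fold lower number from compound 2 to compound 3 (1.00 log units; beyond the scatter) both show that the aryl amide separates from the two small alkyl amides.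

Compound 4 carries the change (pyridin-3-yl in place of 4-methoxyphenyl on a carbonyl carbon). Going by the values given here, no measured step compares two aryl amides with each other; the steps known only tell that a methyl or cyclopropyl group leaves the assay at its limit while a 4-methoxyphenyl group returns a number. Compound 4 is therefore expected near compound 3, with the estimated step of a 1.3-fold higher number from compound 3 to compound 4 (0.12 log units; within the scatter) not beyond the scatter. Compound 4 is expected at 6500 nM, within 2500 nM to 20000 nM.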

Compound 4, half-maximal inhibitory concentration: > 50000 nM
Compound 4 was reported as a limit; the forecaster's own chance of this, stated with the estimate: 12%; middle value at least 7.6-fold (0.88 log units) from the limit.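

In this assay, the step of an at least 10-fold higher number from compound 3 to compound 4 (1.00 log units; beyond the scatter) shows that an aromatic ring on the carbonyl carbon is not enough to return a number: with pyridin-3-yl in place of 4-methoxyphenyl, the result no longer separates from those of the two small alkyl amides. Compound 4 is reported only as a limit, and it sits with those amides there: the limit of > 50000 nM in this assay, at which 3 of the 4 values shown sit. The steps to compound 4 from compound 1 and from compound 2 cannot be read, so pyridin-3-yl cannot be ordered against methyl or cyclopropyl, and of the four groups at this place only 4-methoxyphenyl gives a measured value.

The change replaces a ring carbon with a ring nitrogen and removes the methoxy group in one step, so the compounds shown do not tell which of the two accounts for the loss; a plain phenyl group and a pyridin-3-yl carrying a methoxy group would pull the two apart. They also leave open whether another group on the phenyl ring, such as an amine or a carboxylic acid, would keep a measurable value or move it.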